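This account rests on a few compounds, and the source may have more. Where it says the series, first, only, none or still open, it means among the compounds named here.

Three compounds measured in an assay on tissue (RPTEC cells) for inhibition of solute carrier family 22 member 12 (Homo sapiens), read by scintillation counting, with stated times of 15 min and 2 h (on this read-out lower numbers stand for stronger inhibition and higher numbers for weaker inhibition), set the scene. Compound 1 `COc1cc(C(=O)N2CCc3ccccc32)cc(C#N)c1O` reaches only a limit of the assay, giving > 100000 nM in this assay. Compound 2 `N#Cc1cc(C(=O)N2CCc3ccccc32)cc(Cl)c1O` gives 14700 nM in this assay. For the measured compounds named here, the move an at least 6.8-fold lower number from compound 1 to compound 2 (0.83 log units; beyond the scatter) is the one measured step in this set. Compound 3 `N#Cc1cc(C(=O)N2CS(=O)(=O)c3ccccc32)cc(C2CC2)c1O` gives 19200 nM in this assay, and its number sits close to that of compound 2, within the usual scatter. Going by the values given here, the only other value shown belongs to compound 1 and is a limit of the assay (the limit of > 100000 nM in this assay, at which 1 of the 3 values shown sits).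

Compound 4 `CSc1cc(C(=O)N2CS(=O)(=O)c3ccccc32)cc(C#N)c1O` differs from compound 3 in one place: methylsulfanyl in place of cyclopropyl on an aromatic carbon. Among the compounds with values here, no measured pair in this set swaps a cyclopropyl for a methylsulfanyl, so no step speaks to this change directly. The step from compound 1 to compound 2 touches the same aromatic carbon, but with chloro and methoxy, different groups, and it cannot be carried over as a number. With nothing more to lean on, the expectation for compound 4 is a change of about a 1.6-fold higher number from compound 3 to compound 4 (0.19 log units; within the scatter), that is, little beyond the scatter. The estimated value for compound 4 in this assay is therefore 30000 nM, within a range from 8000 nM to 150000 nM.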

Compound 4, half-maximal inhibitory concentration: 7100 nM
Compound 4: the middle estimate sits 4.2-fold (0.63 log units) above what was measured; the measured number lies below the stated range.
By their numbers in this assay, from the lowest: compound 4; then compounds 2 and 3 (each within the scatter of the next). At a limit, above all of these: compound 1.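

In this assay, the swap on the aromatic carbon ortho to a hydroxy group gives a 2.7-fold lower number from compound 3 to compound 4 (0.43 log units; beyond the scatter), so the read-out tells these two small groups apart even though the methylsulfanyl has no ring and the cyclopropyl does. For the compounds shown here, until now, the only measured change at this carbon was an at least 6.8-fold lower number from compound 1 to compound 2 (0.83 log units; beyond the scatter), which involved different groups on a different core. Both pairs now show a step beyond the scatter, so in the two cores shown, the group on this carbon affects inhibition, and in the core of compound 3 a sulfur-bearing group gives the lower number of the two.

Nothing measured here explains why the methylsulfanyl gives the lower number. As far as these compounds go, it remains open how a longer chain such as ethylsulfanyl, an amine or a carboxylic acid would read on this carbon, and whether methylsulfanyl would give a similar step on the core of compound 1.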